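This account rests on a few compounds, and the source may have more. Where it says the series, first, only, none or still open, it means among the compounds named here.

In a physicochemical assay for metabolic stability, at 30 degrees C, at pH 6.5 (on this read-out lower numbers stand for a shorter-lived compound and higher numbers for a longer-lived compound), compound 1 (`Cc1ccc(CO[P@@]2(=O)OC[C@H]3O[C@@H](n4cnc5c(N)ncnc54)[C@H](O)[C@@H]3O2)cc1`) gives 9.5 h and compound 2 (`Nc1ncnc2c1ncn2[C@@H]1O[C@@H]2CO[P@](=O)(OCc3ccccc3)O[C@H]2[C@H]1O`) gives 9.5 h in the same read-out. Compound 3 (`Nc1ncnc2c1ncn2[C@@H]1O[C@@H]2CO[P@@](=O)(OCc3ccccc3[N+](=O)[O-])O[C@H]2[C@H]1O`) stands lowest of the three at 3 h and lies beyond the scatter from both. For the measured compounds named here, compound 4 (`Nc1ncnc2c1ncn2[C@@H]1O[C@@H]2CO[P@](=O)(OCc3ccccc3[N+](=O)[O-])O[C@H]2[C@H]1O`) is related to compound 3 by the two compounds have the same atoms and bonds and differ only in configuration as drawn: 1 of 5 stereo elements differ; a stereocentre at a phosphorus is drawn R in compound 3 and S in compound 4 as the only change. Going by the values given here, the single measured step of no change at the digits printed from compound 1 to compound 2 (within the scatter) concerns hydrogen in place of methyl on an aromatic carbon, so it gives no direct guide to a change at phosphorus. Among the compounds with values here, no measured pair isolates that change. The step expected in this assay is a 1.3-fold higher number from compound 3 to compound 4 (0.12 log units; within the scatter) and it is expected to stay within the scatter, with neither direction favoured. Compound 4 is estimated at 4 h with an expected range from 1.5 h to 10 h for this measurement.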

Compound 4, half-life: 9.5 h
Compound 4: the middle estimate sits 2.4-fold (0.38 log units) below what was measured; measured number inside the range.
By their numbers in this assay, from the lowest: compound 3; then compounds 1, 2 and 4 (each within the scatter of the next).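

In this assay, for the compounds shown here, the configuration at phosphorus separates two compounds of identical constitution, a step of a 3.2-fold higher number from compound 3 to compound 4 (0.50 log units; beyond the scatter), which no earlier pair could isolate. With the configuration of compound 4, the aromatic changes leave the half-life unmoved: the steps are no change at the digits printed from compound 2 to compound 4 (within the scatter) and no change at the digits printed from compound 1 to compound 4 (within the scatter). The gap between compound 3 and compound 4 can be assigned to phosphorus alone because of one fact: the fact that compounds 3 and 4 differ only in the configuration as drawn.

The compounds shown leave open whether the configuration at phosphorus counts equally without the nitro group. They also leave open how an amine or a carboxylic acid in its place would fare at either configuration.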